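Chain homologation on the hydroxymethyl-bearing core: compound 4

The compounds below may be only part of what the source reports. "The series", "measured", "known", "first", "only" and "open" are said of these compounds alone.

Measured compounds:
compound 1 `c1ccc(CCCNC2CCc3ccsc3CC2)cc1` — 187 nM
compound 2 `c1ccc(CCCCNC2CCc3ccsc3CC2)cc1` — 62 nM
compound 3 `OCc1cc2c(s1)CCC(NCCCc1ccccc1)CC2` — 61 nM

In an assay on membranes from brain for displacement of a labelled ligand from Sigma non-opioid intracellular receptor 1 (Cavia porcellus), read by scintillation counting, with a stated time of 120 min (on this read-out higher numbers stand for weaker inhibition and lower numbers for stronger inhibition), compound 3 gives the lowest of the three numbers, yet compound 2 sits within the scatter of it, so no order between those two can be read; only compound 1 stands apart, as the step of a 3.1-fold lower number from compound 1 to compound 3 (0.49 log units; beyond the scatter) shows.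

Compound 4 `OCc1cc2c(s1)CCC(NCCCCc1ccccc1)CC2` differs from compound 3 in one place: benzyl in place of phenyl on a saturated chain carbon, three bonds along the chain from an amine nitrogen. The same change has been measured once, on the core of compound 1, where it gave a 3.0-fold lower number from compound 1 to compound 2 (0.48 log units; beyond the scatter). Among the compounds with values here, that single step is the only direct guide here, and nothing among the measured compounds speaks against carrying it over to compound 3. The step from compound 3 to compound 4 in this assay is therefore expected to be a lowering of comparable size, a 3.1-fold lower number from compound 3 to compound 4 (0.48 log units; beyond the scatter), beyond the scatter. For compound 4 the estimate in this assay is 20 nM, with a range from 8 nM to 50 nM, the width reflecting that one prior step carries the whole expectation.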

Compound 4, inhibition constant: 84 nM
Compound 4: the middle estimate sits 4.2-fold (0.62 log units) below what was measured; the measured number lies above the stated range.
By their numbers in this assay, from the lowest: compounds 3, 2 and 4 (each within the scatter of the next); then compound 1.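

In this assay, benzyl in place of phenyl does not behave the same on both cores: with the hydroxymethyl group present it gives a 1.4-fold higher number from compound 3 to compound 4 (0.14 log units; within the scatter), so no change can be read, and the lowering seen on the core of compound 1 does not repeat: the same change on two cores in this assay, a 3.0-fold lower number (0.48 log units; beyond the scatter) from compound 1 to compound 2 and a 1.4-fold higher number (0.14 log units; within the scatter) from compound 3 to compound 4, 4.2-fold (0.62 log units) apart, beyond the scatter of two such steps The reverse reading agrees, since hydroxymethyl in place of hydrogen on an aromatic carbon gives a 1.4-fold higher number from compound 2 to compound 4 (0.13 log units; within the scatter), again no readable change, once benzyl is present: the same change on two cores in this assay, a 3.1-fold lower number (0.49 log units; beyond the scatter) from compound 1 to compound 3 and a 1.4-fold higher number (0.13 log units; within the scatter) from compound 2 to compound 4, 4.2-fold (0.62 log units) apart, beyond the scatter of two such steps The two changes therefore do not add up in this small set, and each lowers the number only when the other is absent.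

Within the data shown here, each change has been seen on only two cores. Going by these compounds, whether a longer chain, or a carboxylic acid or an amine in place of hydroxymethyl, would shift the number on this core remains open.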